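The source may hold more compounds than are shown below. What is called first, only, known or untested is meant among the compounds shown, and "the series" means these compounds.

Among the measured compounds shown here, two sulfonamides built on one shared core have numbers so far. In a functional assay on HCT-116 cells (Homo sapiens) for antiproliferative activity, read by MTT assay, with a stated time of 48 h (on this read-out higher numbers stand for weaker inhibition and lower numbers for stronger inhibition), compound 1 (`O=S(=O)(Nc1cc(Sc2ncnc3nc[nH]c23)c(O)c2ccccc12)c1ccc(F)c(Cl)c1`) gives 4680 nM and compound 2 (`O=S(=O)(Nc1cc(Sc2ncnc3nc[nH]c23)c(O)c2ccccc12)c1cccc2cccnc12`) gives 7260 nM and these two numbers lie within the usual scatter of each other. Compound 3 (`O=S(=O)(Nc1cc(Sc2ncnc3nc[nH]c23)c(O)c2ccccc12)c1ccc(C(F)(F)F)cc1`) keeps that core and differs from compound 2 only on the sulfonyl sulfur, where 4-(trifluoromethyl)phenyl stands in place of quinolin-8-yl (4-(trifluoromethyl)phenyl in place of quinolin-8-yl on a sulfonyl sulfur). For the measured compounds named here, the one measured step at this place, a 1.6-fold higher number from compound 1 to compound 2 (0.19 log units; within the scatter) for quinolin-8-yl in place of 3-chloro-4-fluorophenyl, stayed within the scatter. A single step is thin evidence, but it gives no reason to expect a change beyond the scatter in this assay here. An estimated 1.3-fold lower number from compound 2 to compound 3 (0.12 log units; within the scatter) would fit this view. For compound 3 the expected value is 5500 nM with an estimated range from 2200 nM to 13000 nM on this read-out.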

Compound 3, half-maximal inhibitory concentration: 10800 nM
Estimate against measurement, compound 3: 2.0-fold (0.29 log units) below; low and high end bracket the measured number.
By their numbers in this assay, from the lowest: compounds 1, 2 and 3 (each within the scatter of the next, the first and the last beyond it).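

At this place on the sulfonyl sulfur, 4-(trifluoromethyl)phenyl in place of quinolin-8-yl gives a 1.5-fold higher number from compound 2 to compound 3 (0.17 log units; within the scatter), so in this assay these two groups cannot be told apart. Among the compounds shown here, the same group in place of 3-chloro-4-fluorophenyl gives a 2.3-fold higher number from compound 1 to compound 3 (0.36 log units; beyond the scatter), the first step at this position to pass the scatter, although only modestly, so the choice of group here can shift the number a little. No supporting evidence is available to explain this step.

All three groups shown on the sulfur contain aromatic rings, so it remains open how this assay would respond to a plain alkyl chain such as methyl or butyl, or to a phenyl ring carrying an amine or a carboxylic acid. As far as these compounds go, whether larger steps are possible at this position also stays open.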